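A Methyl Added Where No Compound Yet Shows Activity

The compounds below may be only part of what the source reports. "The series", "measured", "known", "first", "only" and "open" are said of these compounds alone.

Compound 1 `CC(C)C(NC(=O)NO)C(=O)NC1CCCCC1` and compound 2 `CCC(C)C(NC(=O)NO)C(=O)NC1CCCCC1` share one core and differ by methyl in place of hydrogen on a saturated chain carbon, three bonds along the chain from an amide-type nitrogen and a carbonyl carbon. In a functional assay on SW-620 cells (Homo sapiens) for inhibition (on this read-out higher numbers stand for weaker inhibition and lower numbers for stronger inhibition), compound 1 reaches only a limit, > 100000 nM. In this assay compound 2 likewise reaches only a limit, > 100000 nM. Between them a step that the two limits leave unreadable from compound 1 to compound 2, because both values sit at the limit of > 100000 nM in this assay, at which 2 of the 3 values shown sit. Compound 3 `CC(C)C(NC(=O)n1nnc2ccccc21)C(=O)NC1CCCC1` carries a different core; the difference between the two cores is not broken down here. In this assay compound 3 also reaches only a limit, > 200000 nM, which is the limit of > 200000 nM in this assay, at which 1 of the 3 values shown sits. Compound 4 `CCC(C)C(NC(=O)n1nnc2ccccc21)C(=O)NC1CCCC1` differs from compound 3 by methyl in place of hydrogen on a saturated chain carbon, three bonds along the chain from an amide-type nitrogen and a carbonyl carbon, the same change as before. Because compound 1 and compound 2 both sit at the limit of > 100000 nM in this assay, at which 2 of the 3 values shown sit, the expected step is a step that the limit leaves unreadable from compound 3 to compound 4, small if anything. Compound 4 is therefore estimated at 250000 nM, within 60000 nM to 1000000 nM, most likely again only a limit.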

Compound 4, half-maximal inhibitory concentration: > 100000 nM
Compound 4 was reported as a limit; the forecaster's own chance of this, stated with the estimate: 85%; the middle value lies beyond the limit too.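

Compound 3 and compound 4 are both reported only as limits, so the step between them cannot be read. The compounds shown leave open whether this added methyl changes inhibition at all.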